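Swapping methyl for 2-chlorophenyl on two related cores

The compounds below may be only part of what the source reports. "The series", "measured", "known", "first", "only" and "open" are said of these compounds alone.

The compounds share a ring-fused amide core and were tested in a functional assay on HCT-15 cells (Homo sapiens) for cytotoxicity, read by sulforhodamine B assay, with a stated time of 72 h; on this read-out lower numbers stand for stronger inhibition of growth and higher numbers for weaker inhibition of growth. Compound 1 `CC(=O)N1c2ccccc2CCC1C(=O)Nc1ccccc1O` gives 54500 nM in this assay. Compound 2 `O=C(Nc1ccccc1O)C1CCc2ccccc2N1C(=O)c1ccccc1Cl` carries the change 2-chlorophenyl in place of methyl on a carbonyl carbon and gives 44900 nM in this assay. The step between them was a 1.2-fold lower number from compound 1 to compound 2 (0.08 log units; within the scatter).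

Compound 3 `CC(=O)N1c2ccccc2CCC1C(=O)Nc1ccccc1C(F)(F)F` differs from compound 1 by trifluoromethyl in place of hydroxy on an aromatic carbon. In this assay compound 3 reaches only > 80000 nM, which is a limit of the assay rather than a number. That value stands at the limit of > 80000 nM in this assay, at which 1 of the 3 values shown sits. The step from the parent is therefore known only as a floor: an at least 1.4-fold higher number from compound 1 to compound 3 (0.16 log units; that floor lies within the scatter).

Compound 4 `O=C(Nc1ccccc1C(F)(F)F)C1CCc2ccccc2N1C(=O)c1ccccc1Cl` has not yet been measured in this assay. It differs from compound 3 by 2-chlorophenyl in place of methyl on a carbonyl carbon, the same change, at the same place, that turns compound 1 into compound 2. For the measured compounds named here, since the first instance of this change lay within the scatter, compound 4 is expected to sit close to compound 3. This expectation rests on the step of a 1.2-fold lower number from compound 1 to compound 2 (0.08 log units; within the scatter). Compound 4 is therefore expected to give about 80000 nM in this assay. Compound 4 is expected to fall between 40000 nM and 200000 nM. Such an estimate amounts to a step of a number no higher from compound 3 to compound 4 (the limit leaves the size open), and a reported limit instead of a number is thought likely.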

Compound 4, concentration for 50% growth inhibition: 4220 nM
Beside the measured number, compound 4's estimate is 19-fold (1.28 log units) above it, and the stated range ends above it.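

In this assay, 2-chlorophenyl in place of methyl on a carbonyl carbon does not carry the same result from one core to the other, as the new step gives an at least 18-fold lower number from compound 3 to compound 4 (1.27 log units; beyond the scatter) and differs from the earlier one: the same change on two cores in this assay, a 1.2-fold lower number (0.08 log units; within the scatter) from compound 1 to compound 2 and an at least 18-fold lower number (1.27 log units; beyond the scatter) from compound 3 to compound 4, at least 15-fold (1.19 log units) apart, beyond the scatter of two such steps The other change, trifluoromethyl in place of hydroxy on an aromatic carbon, also depends on its setting, as it gives an 11-fold lower number from compound 2 to compound 4 (1.03 log units; beyond the scatter) and differs from its earlier counterpart: the same change on two cores in this assay, an at least 1.4-fold higher number (0.16 log units; that floor lies within the scatter) from compound 1 to compound 3 and an 11-fold lower number (1.03 log units; beyond the scatter) from compound 2 to compound 4, at least 15-fold (1.19 log units) apart, beyond the scatter of two such steps Compound 3 stands at > 80000 nM, a limit of the assay and not a number, so the gaps are known only as minimum sizes, and this single set of compounds shows neither why the two changes work together nor whether the same would happen on any further core: the limit of > 80000 nM in this assay, at which 1 of the 4 values shown sits.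

The compounds shown leave open whether the lower number of compound 4 depends on the chlorine or on the ring, which a plain phenyl or a longer alkyl chain on the same carbonyl carbon would help to separate. They also leave open whether trifluoromethyl is the only partner for 2-chlorophenyl, or whether a methoxy group, an amine or a carboxylic acid on that aromatic carbon would give a similar result.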